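An Iodo Swap in a Small Halogen Series

The source may hold more compounds than are shown below. What is called first, only, known or untested is meant among the compounds shown, and "the series" means these compounds.

In a functional assay on T29Kt1 cells (Homo sapiens) for cytotoxicity, read by sulforhodamine B assay, with a stated time of 3 days (a lower number here means a stronger inhibitor, a higher number a weaker inhibitor), compound 1 `OCc1cn(Cc2cccc(F)c2)c2ccccc12` gives 20 nM and compound 2 `OCc1cn(Cc2cccc(Cl)c2)c2ccccc12` gives 160 nM while compound 3 `OCc1cn(Cc2cccc(Br)c2)c2ccccc12` stands at 32 nM on the same scale. Compound 3 sits in the lower pair of numbers, with a 1.6-fold higher number from compound 1 to compound 3 (0.20 log units; within the scatter) and a 5.0-fold lower number from compound 2 to compound 3 (0.70 log units; beyond the scatter) as its two steps. Within the data shown here, compound 4 `OCc1cn(Cc2cccc(I)c2)c2ccccc12` brings iodo in place of bromo on an aromatic carbon as its one change, iodo in place of bromo on an aromatic carbon. The steps among the halogens bear on it, yet an 8.0-fold higher number from compound 1 to compound 2 (0.90 log units; beyond the scatter) is followed by a return of similar size, so they set no direction and no step beyond the scatter is expected. The expected change is a 1.3-fold higher number from compound 3 to compound 4 (0.10 log units; within the scatter) in this assay for this swap. Compound 4 is expected at 40 nM with an estimated range from 12 nM to 140 nM in this measurement.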

Compound 4, half-maximal inhibitory concentration: 20 nM
The estimate for compound 4 lay 2.0-fold (0.30 log units) above the measured number; the measured number falls inside the stated range.
By their numbers in this assay, from the lowest: compounds 1, 4 and 3 (each within the scatter of the next); then compound 2.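

In this assay, iodo on this aromatic carbon stays within the scatter of the other two heavier-contrast neighbours, bromo and fluoro, with a 1.6-fold lower number from compound 3 to compound 4 (0.20 log units; within the scatter) and no change at the digits printed from compound 1 to compound 4 (within the scatter). Chloro alone now stands apart from the other three halogens, with an 8.0-fold lower number from compound 2 to compound 4 (0.90 log units; beyond the scatter), so the numbers do not run in the order fluoro, chloro, bromo, iodo. Nothing measured here explains why compound 2 departs from the rest. The compounds shown leave open whether a group other than a halogen on this carbon, such as methoxy or an amine, would group with compounds 1, 3 and 4 or with compound 2.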